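Swapping one chain for another at the amino acid position

This account rests on a few compounds, and the source may have more. Where it says the series, first, only, none or still open, it means among the compounds named here.

Measured so far:
Compound 1, `CSCC[C@H](NC(=O)CN(c1ncnc2c1ncn2C1CCCCO1)C1CC1)C(=O)OCc1ccccc1`, gives 28.7% in a functional assay on the whole organism (Tail, strain ICR) with Mus musculus as the target, in the tail flick test, with a stated time of 120 min, at a dose of 25 umol/kg by the oral route; a higher number here means a stronger effect of the compound at the dose given, a lower number a weaker effect.
Compound 2, `O=C(O)C[C@H](NC(=O)CN(c1nc(Cl)nc2[nH]cnc12)C1CC1)C(=O)O`, gives 22% in this assay.

Compound 1 has the higher of the two numbers in this assay, but its distance to compound 2 lies within the usual scatter, so the two cannot be ranked against each other. Compound 3, `CC(C)C[C@H](NC(=O)CN(c1ncnc2c1ncn2C1CCCCO1)C1CC1)C(=O)OCc1ccccc1`, has not been measured yet. It differs from compound 1 in one place: isopropyl in place of (methylsulfanyl)methyl on a saturated chain carbon, two bonds along the chain from an amide-type nitrogen and a carbonyl carbon. Among the measured compounds shown here, no pair of measured compounds shows what such a change does here, so nothing sets the size of the step from compound 1 to compound 3, and a step of no more than the scatter is expected in either direction. Against that background the estimated step of a number 2.7 percentage points lower from compound 1 to compound 3 (within the scatter) is small. Compound 3 is therefore expected to give about 26% in this assay, with a range from 10% to 42%.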

Compound 3, a percentage reported as activity, at one dose (the size of the read-out at that dose, not a potency): 12.8%
Compound 3: middle estimate off by 13.2 percentage points, on the high side, within the range that was stated.
By their numbers in this assay, from the lowest: compounds 3, 2 and 1 (each within the scatter of the next, the first and the last beyond it).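

Placing isopropyl where compound 1 carries (methylsulfanyl)methyl gives a number 15.9 percentage points lower from compound 1 to compound 3 (beyond the scatter) in this assay, the first step that can be read at this position. The two groups have the same count of heavy atoms, so the read-out at this dose responds to what this chain is made of and how it is arranged, not only to its size. Nothing measured here explains why the number falls.

This single pair cannot separate the loss of the sulfur and its hydrogen-bond acceptor from the change in the shape of the chain, and 2-(methylsulfanyl)ethyl and isobutyl are simply two readings of the same swap. From the compounds shown here alone, how an amine, a hydroxyl group or a longer chain such as n-hexyl would read at this position remains open.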